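This account rests on a few compounds, and the source may have more. Where it says the series, first, only, none or still open, it means among the compounds named here.

Working notes on the series. The measured set holds compound 1 `Cc1ccnc(/C(N)=N/NC(=S)N2CCOCC2)c1` and compound 2 `Cc1cccc(/C(N)=N/NC(=S)N2CCSCC2)n1`. In a functional assay on HeLa cells (Homo sapiens) for cytotoxicity, read by MTT assay, with a stated time of 72 h, tested at 100 uM (on this read-out lower numbers stand for less inhibition of growth and higher numbers for more inhibition of growth at the one concentration tested), compound 1 gives 82.7%, and in this assay compound 2 gives 81.6%; compound 2 stands lowest of the two numbers, with compound 1 the nearest and within the scatter. Compound 3 `N/C(=N\NC(=S)N1CCSCC1)c1ccccn1` is not yet measured. It differs from compound 2 by hydrogen in place of methyl on an aromatic carbon. Within the data shown here, no measured pair covers such a change, so the expected step in this assay is a number 3.6 percentage points lower from compound 2 to compound 3 (within the scatter), small and not clearly beyond the scatter. Compound 3 is estimated at 78%, in a range from 60% to 92%.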

Compound 3, percent growth inhibition at one concentration: 88.7%
Compound 3: middle estimate off by 10.7 percentage points, on the low side, within the range that was stated.
By their numbers in this assay, from the lowest: compounds 2, 1 and 3 (each within the scatter of the next).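

In this assay, among these compounds, the first pair for this change, hydrogen in place of methyl on an aromatic carbon next to the ring nitrogen, gives a number 7.1 percentage points higher from compound 2 to compound 3 (within the scatter), so the read-out at the one concentration tested does not depend on the methyl at this position. Nothing at hand bears on the reason for the size of this step.

From the compounds shown here alone, whether an amine, a carboxylic acid or a longer chain at this position would keep the read-out within the scatter remains open. A single concentration also leaves open whether compound 2 and compound 3 would separate at lower concentrations.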